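Swapping methyl for bromo on the aryl ring of compound 1

The compounds below may be only part of what the source reports. "The series", "measured", "known", "first", "only" and "open" are said of these compounds alone.

Compound 1 `COc1ccccc1Oc1c(N)nc(-c2cccc(C)c2)nc1Cl` gives 11200 nM in a toxicity assay on HaCaT cells (Homo sapiens) for cytotoxicity, read by CCK-8 assay, with a stated time of 24 h (a higher number here means that more compound is tolerated, a lower number that less compound is tolerated), the lowest of the two numbers measured; compound 2 `COc1ccccc1Oc1c(N)nc(-c2ccc(F)cc2)nc1Cl` gives 42600 nM. Among the compounds with values here, the only measured step changes the same ring: a 3.8-fold higher number from compound 1 to compound 2 (0.58 log units; beyond the scatter). Compound 3 `COc1ccccc1Oc1c(N)nc(-c2cccc(Br)c2)nc1Cl` differs from compound 1 by bromo in place of methyl on an aromatic carbon. That step touches the same ring as the measured step but a different group, so only a weak guide exists; a small change, if any, is expected. Compound 3 is therefore expected to give 15000 nM (range 5000 nM to 45000 nM), a step of a 1.3-fold higher number from compound 1 to compound 3 (0.13 log units; within the scatter).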

Compound 3, half-maximal cytotoxic concentration: 16100 nM
For compound 3 the middle estimate is 1.1-fold (0.03 log units) below the measured one, and the stated range covers the measured number.
By their numbers in this assay, from the lowest: compounds 1 and 3 (each within the scatter of the next); then compound 2.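

In this assay, bromo and methyl at this place on the ring cannot be told apart, with a 1.4-fold higher number from compound 1 to compound 3 (0.16 log units; within the scatter). Changing the group here need not shift the number, while a 2.6-fold lower number from compound 2 to compound 3 (0.42 log units; beyond the scatter) keeps the 4-fluorophenyl compound apart from the 3-bromophenyl one. Nothing available bears on the reason for these numbers.

Compound 2 and compound 3 differ in both the group and its place on the ring, so those two changes remain unseparated. On these data alone, how this place would respond to an amine or a carboxylic acid also remains open.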